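The source may report more compounds than this note shows. Statements on the series, on what has been measured and on what is new or still open speak of the compounds shown alone.

Measured compounds in a functional assay on CHO cells for positive allosteric modulation of muscarinic acetylcholine receptor M5 (Homo sapiens), read by FLIPR and calcium flux, with a stated time of 1 h; on this read-out higher numbers stand for an effect only at larger amounts of compound and lower numbers for an effect already at smaller amounts:
- compound 1, `O=C1C(=O)N(Cc2ccc(-c3cccnc3)cc2)c2ccc(OC(F)(F)F)cc21`, gives 1600 nM
- compound 3, `O=C1C(=O)N(Cc2ccc(-c3ccccc3)nc2)c2ccc(OC(F)(F)F)cc21`, gives 3800 nM
- compound 2, `O=C1C(=O)N(Cc2cccc(Oc3ccccc3)c2)c2ccc(OC(F)(F)F)cc21`, gives only a limit of the assay, > 30000 nM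

Compound 1 holds the lowest of the two numbers obtained; compound 3 sits above it, and that gap is beyond the usual scatter. Compound 2 returned no number at all, only the limit (the limit of > 30000 nM in this assay, at which 1 of the 3 values shown sits), so it cannot be ranked against the other two.

The next compound, compound 4, `O=C1C(=O)N(Cc2ccc(Oc3cccc(F)n3)cc2)c2ccc(OC(F)(F)F)cc21`, keeps the shared core of compound 1 and changes one group: (6-fluoropyridin-2-yl)oxy in place of pyridin-3-yl on an aromatic carbon. The aryl ring that was attached directly is thus replaced by an aryl ring attached through an oxygen, and a fluorine is added to that ring. Among the measured compounds shown here, no directly measured step of this kind exists; the only other compound carrying an aryloxy group, compound 2, gave a limit, but its arrangement differs in more than one respect from compound 4, so it shows only that aryloxy groups can fall outside the measured window.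

For compound 4 the expectation is a step from compound 1 of a 3.1-fold higher number from compound 1 to compound 4 (0.49 log units; beyond the scatter) in this assay, toward a higher number. Compound 4 is estimated at 5000 nM, with a range from 1500 nM to 20000 nM.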

Compound 4, half-maximal effective concentration: 1500 nM
Compound 4: middle estimate off by 3.3-fold (0.52 log units), on the high side; the range from low to high includes it.
By their numbers in this assay, from the lowest: compounds 4 and 1 (each within the scatter of the next); then compound 3. At a limit, above all of these: compound 2.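

At this place, on an aromatic carbon para to a large group, (6-fluoropyridin-2-yl)oxy in place of pyridin-3-yl gives a 1.1-fold lower number from compound 1 to compound 4 (0.03 log units; within the scatter) in this assay, so the two groups cannot be told apart on this read-out. An aryl ring attached through an oxygen and carrying a fluorine therefore still returns a number at this place, which shows that an aryloxy group here does not by itself lead out of the measured window. Compound 2, the only other aryloxy compound, remains a limit of the assay and differs from compound 4 in more than one respect, so no step between them can be read: the limit of > 30000 nM in this assay, at which 1 of the 4 values shown sits.

The oxygen and the fluorine enter together in this one step, and the compounds shown do not separate what each contributes to the result. Also open, from the compounds shown here alone, is how this assay responds at this place to a pyridin-2-yloxy group without the fluorine, or to an aryloxy ring carrying an amine or a carboxylic acid.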